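Compound 4 Weighed Against Compound 3

The compounds below may be only part of what the source reports. "The series", "measured", "known", "first", "only" and "open" are said of these compounds alone.

Of the compounds shown here, three have so far been measured in an assay for binding affinity to leukotriene B4 receptor 1 (Homo sapiens); on this read-out higher numbers stand for weaker inhibition and lower numbers for stronger inhibition. Compound 1 `COc1ccc(CCCCCCCCOc2ccc(C[S+]([O-])c3ccccc3)nc2/C=C/C(=O)O)cc1` gives 37 nM. Compound 2 `CCCCCCCCCCCCOc1ccc(C[S+]([O-])c2cccc(C(=O)O)c2)nc1/C=C/C(=O)O` gives 129 nM. Compound 3 `COc1ccc(CCCCCCCCOc2ccc(C[S+]([O-])c3cccc(C(=O)O)c3)nc2/C=C/C(=O)O)cc1` gives 151 nM, the highest of the three numbers; compound 2 stands nearest to it and compound 1 furthest. The step of a 4.1-fold higher number from compound 1 to compound 3 (0.61 log units; beyond the scatter) lies beyond the scatter, while the step of a 1.2-fold higher number from compound 2 to compound 3 (0.07 log units; within the scatter) lies within it.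

Compound 4 `COc1ccc(CCCCCCCCOc2ccc(CSc3cccc(C(=O)O)c3)nc2/C=C/C(=O)O)cc1` differs from compound 3 in a single place: a group of 10 heavy atoms (7 carbon, 2 oxygen, 1 sulfur; one six-membered aromatic ring of carbon only) in place of a group of 11 heavy atoms (7 carbon, 3 oxygen, 1 sulfur; one six-membered aromatic ring of carbon only), on a saturated chain carbon bound to an aromatic carbon. Neither of the measured steps bears on this exchange: one puts a carboxy group onto an aromatic carbon, the other replaces butyl by 4-methoxyphenyl at the end of the saturated chain, and both leave the group in question untouched. The measured compounds therefore give no guide to the direction of this step, and the plainest expectation is a number close to that of compound 3, with a step not beyond the scatter but with a wide allowance for uncertainty.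

Compound 4 is thus expected to give 150 nM, within a range from 45 nM to 500 nM. This estimate amounts to an expected step of a 1.0-fold lower number from compound 3 to compound 4 (0.00 log units; within the scatter).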

Compound 4, inhibition constant: 80 nM
Beside the measured number, compound 4's estimate is 1.9-fold (0.27 log units) above it, and the stated range covers the measured number.
By their numbers in this assay, from the lowest: compound 1; then compounds 4, 2 and 3 (each within the scatter of the next).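

Among these compounds, at this position, on a saturated chain carbon bound to an aromatic carbon, compound 4 is the first to alter the sulfur-bearing group while keeping its carboxy group, and in this assay the (3-carboxyphenyl)sulfanyl group in place of the group with one more oxygen gives a 1.9-fold lower number from compound 3 to compound 4 (0.28 log units; within the scatter), so this single oxygen makes no difference that can be told from the scatter. The comparison with the group lacking the carboxy reads differently, with a 2.2-fold higher number from compound 1 to compound 4 (0.33 log units; beyond the scatter), a modest separation that remains beyond the scatter even with that oxygen gone, although this exchange alters the oxygen count and adds the carboxy group in one step, so the two contributions cannot be told apart. No measurement is available that would account for either step.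

The compounds shown leave open how a plain phenylsulfanyl group, with neither the extra oxygen nor the carboxy group, would read at this position, which would separate those two contributions. They also leave open how a sulfonyl group with two oxygens on the sulfur would compare, and whether the oxygen exchange would read the same on the long saturated chain of compound 2.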